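Working notes: phenyl to 2-hydroxyphenyl

The compounds below may be only part of what the source reports. "The series", "measured", "known", "first", "only" and "open" are said of these compounds alone.

Measured in a functional assay on MDA-MB-468 cells (Homo sapiens) for inhibition, read by MTT assay; a higher number here means a weaker inhibitor of growth, a lower number a stronger inhibitor of growth:
- compound 1 `CC1=C(/C=C/C(C)=C/C=C/C(C)=C\C(=O)Nc2ccccc2)C(C)(C)CCC1n1ccnc1`: 2540 nM
- compound 2 `CC1=C(/C=C/C(C)=C/C=C/C(C)=C\C(=O)Nc2ccc(F)cc2)C(C)(C)CCC1n1ccnc1`: 4570 nM

Compound 1 has only compound 2 for comparison, and the two values lie within the scatter of each other. Compound 3 `CC1=C(/C=C/C(C)=C/C=C/C(C)=C\C(=O)Nc2ccccc2O)C(C)(C)CCC1n1ccnc1` differs from compound 1 by hydroxy in place of hydrogen on an aromatic carbon. For the measured compounds named here, the only measured step, a 1.8-fold higher number from compound 1 to compound 2 (0.26 log units; within the scatter), also replaces hydrogen on an aromatic carbon, but with fluoro, and stays within the scatter. No step beyond the scatter is therefore expected in this assay, though this single step says little about hydroxy. The estimate for compound 3 is 2000 nM, with an expected range of 600 nM to 6000 nM. The estimated step is a 1.3-fold lower number from compound 1 to compound 3 (0.10 log units; within the scatter).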

Compound 3, concentration for 50% growth inhibition: 3030 nM
Compound 3: middle estimate off by 1.5-fold (0.18 log units), on the low side, and the stated range covers the measured number.
By their numbers in this assay, from the lowest: compounds 1, 3 and 2 (each within the scatter of the next).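

The hydroxy group, placed ortho to a large group on the aromatic ring, leaves the number in this assay within the scatter (a 1.2-fold higher number from compound 1 to compound 3 (0.08 log units; within the scatter)). For the compounds shown here, exchanging 4-fluorophenyl for 2-hydroxyphenyl on the amide-type nitrogen also stays within the scatter (a 1.5-fold lower number from compound 2 to compound 3 (0.18 log units; within the scatter)), so neither change separates compound 3 from the earlier compounds. No available evidence bears on this result.

From the compounds shown here alone, whether an amine, a carboxylic acid or a methoxy group in place of this hydroxy would give a step beyond the scatter remains open.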